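Swapping a Hydroxyphenyl Arm on a Pyridine-Free Core Account

The source may report more compounds than this note shows. Statements on the series, on what has been measured and on what is new or still open speak of the compounds shown alone.

Measured compounds:
compound 1 `Oc1cccc(-c2cc(-c3cccc(F)c3)cc(-c3cccc(O)c3)n2)c1` 21300 nM
compound 2 `Oc1ccc(-c2cc(-c3cccc(F)c3)cc(-c3cccc(O)c3)n2)cc1` 3510 nM
compound 3 `Oc1cccc(-c2cc(-c3cccc(OC(F)(F)F)c3)cc(-c3cccc(O)c3)n2)c1` 6740 nM

Of the compounds shown here, three have been tested in a functional assay on T47D cells (Homo sapiens) for inhibition; a higher number here means a weaker inhibitor, a lower number a stronger inhibitor. Compound 1 `Oc1cccc(-c2cc(-c3cccc(F)c3)cc(-c3cccc(O)c3)n2)c1` gives 21300 nM in this assay. Compound 2 `Oc1ccc(-c2cc(-c3cccc(F)c3)cc(-c3cccc(O)c3)n2)cc1` differs from it by 4-hydroxyphenyl in place of 3-hydroxyphenyl on an aromatic carbon and gives 3510 nM in this assay, a change of a 6.1-fold lower number from compound 1 to compound 2 (0.78 log units; beyond the scatter). Compound 3 `Oc1cccc(-c2cc(-c3cccc(OC(F)(F)F)c3)cc(-c3cccc(O)c3)n2)c1` differs from compound 1 by trifluoromethoxy in place of fluoro on an aromatic carbon. In this assay compound 3 gives 6740 nM, a change of a 3.2-fold lower number from compound 1 to compound 3 (0.50 log units; beyond the scatter). Compounds 2 and 3 lie within the scatter of each other.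

Compound 4 `Oc1ccc(-c2cc(-c3cccc(OC(F)(F)F)c3)cc(-c3cccc(O)c3)n2)cc1` has not yet been measured in this assay. It differs from compound 3 by 4-hydroxyphenyl in place of 3-hydroxyphenyl on an aromatic carbon. This is the same kind of change that was made from compound 1 to compound 2, though the surroundings are not identical: in the earlier pair the place is meta to a 3-fluorophenyl group, whereas in compound 3 it is meta to a large group, the cores differing by the trifluoromethoxy in place of fluoro just described. Within the data shown here, the expectation for compound 4 rests on the single earlier instance, which gave a 6.1-fold lower number from compound 1 to compound 2 (0.78 log units; beyond the scatter). The estimated step from compound 3 to compound 4 is therefore a 4.8-fold lower number from compound 3 to compound 4 (0.68 log units; beyond the scatter), set a little smaller than the earlier one. That earlier step is a lone observation, and the core has changed. Compound 4 is accordingly expected to give about 1400 nM in this assay, plausibly between 450 nM and 4500 nM.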

Compound 4, half-maximal inhibitory concentration: 5040 nM
The estimate for compound 4 lay 3.6-fold (0.56 log units) below the measured number; the whole stated range lies below it.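

In this assay, 4-hydroxyphenyl in place of 3-hydroxyphenyl on the core bearing trifluoromethoxy gives a 1.3-fold lower number from compound 3 to compound 4 (0.13 log units; within the scatter), and this step does not match the one seen on the core bearing fluoro: the same change on two cores in this assay, a 6.1-fold lower number (0.78 log units; beyond the scatter) from compound 1 to compound 2 and a 1.3-fold lower number (0.13 log units; within the scatter) from compound 3 to compound 4, 4.5-fold (0.66 log units) apart, beyond the scatter of two such steps. Trifluoromethoxy in place of fluoro, made with the 4-hydroxyphenyl arm already present, gives a 1.4-fold higher number from compound 2 to compound 4 (0.16 log units; within the scatter), and it too fails to repeat its earlier step: the same change on two cores in this assay, a 3.2-fold lower number (0.50 log units; beyond the scatter) from compound 1 to compound 3 and a 1.4-fold higher number (0.16 log units; within the scatter) from compound 2 to compound 4, 4.5-fold (0.66 log units) apart, beyond the scatter of two such steps. Within these four compounds, then, neither change can be carried from one core to the other at its earlier size, and each step depends on what the other place holds, but this rests on a single set of compounds in a single assay and does not show why the steps differ or whether the same would hold on any other core.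

The compounds shown leave open whether the hydroxyphenyl swap would keep its larger or its smaller size with a methoxy group, a chloro group or a nitrile in place of fluoro or trifluoromethoxy. They also leave open what an amine or a carboxylic acid would do in place of the hydroxyl on the swapped arm.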